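Bromophenyl placement in the bicyclic lactam triazole series

A few compounds are considered here, and "the series" means these few. Any claim that something is new, unique, unknown or untested is made for them only; others in the source may bear on it.

The series shares one core, seen in compound 1 `CC1(C)[C@H]2CC[C@]1(C)N(Cc1cn(-c3ccc(Cl)cc3)nn1)C(=O)C2`, compound 2 `CC1(C)[C@H]2CC[C@]1(C)N(Cc1cn(-c3ccccc3C#N)nn1)C(=O)C2` and compound 3 `CC1(C)[C@H]2CC[C@]1(C)N(Cc1cn(-c3ccccc3Br)nn1)C(=O)C2`, and varies only the aryl group on the triazole nitrogen. In a functional assay on OVCAR-3 cells (Homo sapiens) for inhibition, read by MTT assay, with a stated time of 24 h (on this read-out higher numbers stand for weaker inhibition and lower numbers for stronger inhibition), compound 1 gives 160 nM, compound 2 gives 110 nM and compound 3 gives 140 nM. Compound 3 stands second highest of the three numbers, but every step shown is within the scatter: a 1.1-fold lower number from compound 1 to compound 3 (0.06 log units; within the scatter), a 1.5-fold lower number from compound 1 to compound 2 (0.16 log units; within the scatter), a 1.3-fold higher number from compound 2 to compound 3 (0.10 log units; within the scatter). The aryl changes measured so far therefore leave this assay essentially unmoved.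

Compound 4 `CC1(C)[C@H]2CC[C@]1(C)N(Cc1cn(-c3ccc(Br)cc3)nn1)C(=O)C2` differs from compound 3 by 4-bromophenyl in place of 2-bromophenyl on an aromatic nitrogen. The nearest measured comparison is compound 1, which carries a 4-chlorophenyl group and sits within the scatter of compound 3, as a 1.1-fold lower number from compound 1 to compound 3 (0.06 log units; within the scatter) shows; likewise the 2-bromophenyl of compound 3 and the 2-cyanophenyl of compound 2 give numbers within the scatter of each other. Within the data shown here, no measured step in this assay rises beyond the scatter, so for compound 4 a change of a 1.1-fold higher number from compound 3 to compound 4 (0.03 log units; within the scatter) is expected, that is, none beyond the scatter. Compound 4 is therefore estimated at 150 nM, with a range of 75 nM to 300 nM in this assay.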

Compound 4, half-maximal inhibitory concentration: 140 nM
Compound 4: middle estimate off by 1.1-fold (0.03 log units), on the high side; the range from low to high includes it.
By their numbers in this assay, from the lowest: compounds 2, 3, 4 and 1 (each within the scatter of the next).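

In this assay, among these compounds, 4-bromophenyl in place of 2-bromophenyl on the aromatic nitrogen gives no change at the digits printed from compound 3 to compound 4 (within the scatter) and is the first pair to keep the same substituent while altering its placement on the phenyl ring, so for bromo this read-out does not separate the two placements. Among the compounds shown here, the new compound also supplies the first direct halogen exchange at a fixed placement, where going from chloro to bromo gives a 1.1-fold lower number from compound 1 to compound 4 (0.06 log units; within the scatter), while 4-bromophenyl in place of 2-cyanophenyl on the aromatic nitrogen gives a 1.3-fold higher number from compound 2 to compound 4 (0.10 log units; within the scatter) and thus adds a third aryl comparison within the scatter. No supporting data are available to explain why these aryl groups read alike.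

All four compounds shown carry a halogen or nitrile on the phenyl ring, so it remains open whether this assay would stay this flat with an amine or a carboxylic acid on that ring. Also open, from the compounds shown here alone, is what an unsubstituted phenyl, or a longer alkyl chain in place of the aryl group, would do on the shared core.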